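Swapping a piperidine link on a benzimidazole core

The source may hold more compounds than are shown below. What is called first, only, known or untested is meant among the compounds shown, and "the series" means these compounds.

Measured so far:
- Compound 1 `CN1CCC[C@H](Cn2c(CN(C)[C@@H]3CCCc4cccnc43)nc3ccccc32)C1` gives 3600 nM in an ADME assay on HOS cells (Homo sapiens) for cytotoxicity; on this read-out lower numbers stand for higher toxicity in this test and higher numbers for lower toxicity in this test.
- Compound 2 `CN1CCCCC1CCn1c(CN(C)C2CCCc3cccnc32)nc2ccccc21` gives 4900 nM in this assay.

Only these two numbers exist for this series. Compound 2 stands alongside compound 1: the gap between the two values lies within the usual scatter of repeated measurements, so neither can be called the more or less toxic of the pair.

Compound 3 `CN1CCCC(Cn2c(CN(C)C3CCCc4cccnc43)nc3ccccc32)C1` has not been measured. It differs from compound 2 in one place: 1-methylpiperidin-3-yl in place of (1-methylpiperidin-2-yl)methyl on a saturated chain carbon bound to an aromatic nitrogen. The group that leaves and the group that enters are close in size and share the same ring type and the same count of donors and acceptors.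

Among the compounds with values here, with no measured step of this kind to lean on, and with compound 1 and compound 2 sitting so near each other, a step from compound 2 to compound 3 is expected to stay within the scatter, in either direction, at about a 1.2-fold lower number from compound 2 to compound 3 (0.09 log units; within the scatter). Compound 3 is therefore estimated at 4000 nM in this assay, most likely between 2000 nM and 8000 nM.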

Compound 3, half-maximal cytotoxic concentration: 3000 nM
Compound 3: the middle estimate sits 1.3-fold (0.12 log units) above what was measured; the measured number falls inside the stated range.
By their numbers in this assay, from the lowest: compounds 3, 1 and 2 (each within the scatter of the next).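

Replacing (1-methylpiperidin-2-yl)methyl with 1-methylpiperidin-3-yl, on a saturated chain carbon bound to an aromatic nitrogen, gives in this assay a 1.6-fold lower number from compound 2 to compound 3 (0.21 log units; within the scatter). This single change of ring attachment and link therefore leaves the read-out inside the scatter. Compound 3 also has the same atoms and bonds as compound 1, with a 1.2-fold lower number from compound 1 to compound 3 (0.08 log units; within the scatter), but this pair says little about spatial arrangement because a drawn configuration is set against an undrawn one: the fact that one of compounds 1 and 3 is drawn with a defined configuration and the other without, at the place where they differ

From the compounds shown here alone, whether the individual mirror-image forms of compound 3 would give matching numbers stays open. Also open, going by these compounds, is whether a more different group at this place, such as a primary amine, a carboxylic acid or a longer chain carrying a morpholine ring, would shift the number beyond the scatter.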